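A few compounds are considered here, and "the series" means these few. Any claim that something is new, unique, unknown or untested is made for them only; others in the source may bear on it.

Measured compounds in a functional assay on SK-BR-3 cells (Homo sapiens) for antiproliferative activity; on this read-out lower numbers stand for stronger inhibition and higher numbers for weaker inhibition:
compound 1 `COc1cccc(Oc2ccc3cc(NC(=O)c4ccc(OC(C)=O)c(CC=C(C)C)c4)c(=O)oc3c2C)c1`, 13700 nM
compound 2 `COc1ccc(Oc2ccc3cc(NC(=O)c4ccc(OC)c(-c5cccc(OC)c5)c4)c(=O)oc3c2C)cc1`, > 100000 nM
compound 3 `COc1cccc(Oc2ccc3cc(NC(=O)c4ccc(OC)c(-c5cccc(OC)c5)c4)c(=O)oc3c2C)c1`, > 100000 nM

Compound 1 is the only one of the three with a number; in this assay compound 1 gives 13700 nM. Compound 2 reaches only a limit of the assay, > 100000 nM. Compound 3 likewise reaches only a limit, > 100000 nM, and thus stands at the limit of > 100000 nM in this assay, at which 2 of the 3 values shown sit. The step that the two limits leave unreadable from compound 2 to compound 3 is consequently not readable. Within the data shown here, compound 1 differs from compound 3 in more than one place, so no single step connects them.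

Compound 4 `COc1ccc(Nc2ccc3cc(NC(=O)c4ccc(OC)c(-c5cccc(OC)c5)c4)c(=O)oc3c2C)cc1` arises from compound 3 through ((4-methoxyphenyl)amino in place of 3-methoxyphenoxy on an aromatic carbon). None of the measured steps bears on this change, and the starting point is itself a limit, so no direction can be drawn from the numbers shown. The step of a number no higher from compound 3 to compound 4 (the limit leaves the size open) is therefore expected to be none beyond the scatter, with wide uncertainty in both directions. Compound 4 is estimated at 100000 nM, with a range from 20000 nM to 400000 nM, and most likely it too reports only a limit.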

Compound 4, half-maximal inhibitory concentration: > 100000 nM
Compound 4: only a limit was reported; the forecaster's own chance of this, stated with the estimate: 65%; the middle value lies on the limit itself.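

In this assay compound 4 gives only a limit, > 100000 nM. Among these compounds, compound 2 and compound 3 are limits too, so no new step to compound 4 can be read. The compounds shown leave open how far (4-methoxyphenyl)amino and the methoxyphenoxy groups differ in this read-out.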